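This account rests on a few compounds, and the source may have more. Where it says the series, first, only, none or still open, it means among the compounds named here.

Of the compounds shown here, three built on one shared core have been tested in an ADME assay on CHO cells (Cricetulus griseus) for inhibition, read by MTT assay; on this read-out higher numbers stand for weaker inhibition and lower numbers for stronger inhibition. Among the measured compounds shown here, compound 3 `CCN(CC)Cc1cc(C)cc(Nc2nc3ccccc3n2Cc2ccc(F)cc2)c1O` gives 18700 nM in this assay, one of only two numbers recorded, and compound 1 `CCNCc1cc(C)cc(Nc2nc3ccccc3n2Cc2ccc(C(F)(F)F)cc2)c1O` with 18800 nM lies within the usual scatter of that value. Compound 2 `CCN(CC)Cc1cccc(Nc2nc3ccccc3n2Cc2ccc(C(F)(F)F)cc2)c1O` is recorded as > 50000 nM, which is the limit of > 50000 nM in this assay, at which 1 of the 3 values shown sits, a limit rather than a number. Compound 4 `CCN(CC)Cc1cc(C)cc(Nc2nc3ccccc3n2Cc2ccc(C(F)(F)F)cc2)c1O` has not been measured yet. It differs from compound 3 in one place: trifluoromethyl in place of fluoro on an aromatic carbon. For the measured compounds named here, no measured pair here differs in just one place, so no step can be leaned on; the change is expected to move the number little, if at all, beyond the scatter. Compound 4 is estimated at 20000 nM, between 8000 nM and 55000 nM, an expected step of a 1.1-fold higher number from compound 3 to compound 4 (0.03 log units; within the scatter).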

Compound 4, half-maximal inhibitory concentration: 29300 nM
Compound 4: middle estimate off by 1.5-fold (0.17 log units), on the low side; measured number inside the range.
By their numbers in this assay, from the lowest: compounds 3, 1 and 4 (each within the scatter of the next). At a limit, above all of these: compound 2.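

In this assay, replacing hydrogen with ethyl on the amine nitrogen gives a 1.6-fold higher number from compound 1 to compound 4 (0.19 log units; within the scatter), and going from 4-fluorobenzyl to 4-(trifluoromethyl)benzyl gives a 1.6-fold higher number from compound 3 to compound 4 (0.20 log units; within the scatter), so neither single change moves the number beyond the scatter. Replacing hydrogen with methyl on an aromatic carbon gives an at least 1.7-fold lower number from compound 2 to compound 4 (0.23 log units; that floor lies within the scatter), which fixes only a floor for that step. Compound 2 stands at a limit rather than a number: the limit of > 50000 nM in this assay, at which 1 of the 4 values shown sits.

As far as these compounds go, the full size of the methyl step stays open. Also open, from the compounds shown here alone, is whether a nitrile, an amine or a carboxylic acid in place of the trifluoromethyl would move the number beyond the scatter.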